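Hydroxy Added Ortho to the Carboxy Group: Expected Effect

The source may report more compounds than this note shows. Statements on the series, on what has been measured and on what is new or still open speak of the compounds shown alone.

This account follows one change on an anilide-type core. Compound 1 `O=C(O)c1ccc(N2C(=O)C=CC2=O)cc1` carries a carboxy group on its six-membered aromatic ring. In an ADME assay on MT2 cells (Homo sapiens) for cytotoxicity, read by XTT assay, with a stated time of 4 days (on this read-out lower numbers stand for higher toxicity in this test and higher numbers for lower toxicity in this test), compound 1 gives > 400000 nM, which is a limit of the assay rather than a number; compound 1 therefore sits at the limit of > 400000 nM in this assay, at which 1 of the 2 values shown sits, and only a limit is known for it. Compound 2 `N#CSCc1nc(-c2ccc(C(=O)O)cc2)no1` is built on a different core, and in this assay compound 2 gives 383000 nM. Within the data shown here, no step between measured compounds is recorded here.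

Compound 3 `O=C(O)c1ccc(N2C(=O)C=CC2=O)cc1O` differs from compound 1 by hydroxy in place of hydrogen on an aromatic carbon. Among the measured compounds shown here, no measured step offers a guide, and the expected change in this assay from such a hydroxy addition is none beyond the usual scatter. For compound 3 the estimated half-maximal cytotoxic concentration in this assay is 400000 nM, with a range from 200000 nM to 800000 nM, which means an expected step of a number no higher from compound 1 to compound 3 (the limit leaves the size open).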

Compound 3, half-maximal cytotoxic concentration: > 400000 nM
Compound 3: no number, only a limit; the forecaster's own chance of this, stated with the estimate: 70%; the middle value sits exactly at the limit.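

No step can be read between compound 1 and compound 3, because each gives only a limit and not a number: the limit of > 400000 nM in this assay, at which 2 of the 3 values shown sit.

The compounds shown leave open whether hydroxy in place of hydrogen, ortho to a carboxy group, changes the half-maximal cytotoxic concentration at all.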